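The compounds below may be only part of what the source reports. "The series", "measured", "known", "first", "only" and "open" are said of these compounds alone.

Of the compounds shown here, two of a shared core have been measured in an ADME assay on HaCaT cells (Homo sapiens) for antiproliferative activity, read by MTT assay, with a stated time of 48 h; on this read-out higher numbers stand for weaker inhibition and lower numbers for stronger inhibition. Compound 1 `COc1ccc(N/C=C\C(=O)c2cn(-c3ccccc3)nc2-c2ccc(F)cc2)cc1` gives 19600 nM. Compound 2 `O=C(/C=C\Nc1ccc(Cl)cc1)c1cn(-c2ccccc2)nc1-c1ccc(Cl)cc1` gives 23400 nM, and the two numbers lie within the usual scatter of each other, so this assay does not tell compound 1 and compound 2 apart. Compound 3 `COc1ccc(N/C=C\C(=O)c2cn(-c3ccccc3)nc2-c2ccc(Cl)cc2)cc1` has not yet been measured. It differs from compound 2 by methoxy in place of chloro on an aromatic carbon. Because the values of compound 1 19600 nM and compound 2 23400 nM are indistinguishable, no shift beyond the scatter is expected, and the step of a 1.1-fold lower number from compound 2 to compound 3 (0.05 log units; within the scatter) is estimated as essentially flat. Compound 3 is therefore expected to give about 21000 nM, in a range from 10000 nM to 42000 nM.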

Compound 3, half-maximal inhibitory concentration: 30800 nM
Estimate against measurement, compound 3: 1.5-fold (0.17 log units) below, and the stated range covers the measured number.
By their numbers in this assay, from the lowest: compounds 1, 2 and 3 (each within the scatter of the next).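

In this assay, putting methoxy in place of chloro on an aromatic carbon gives a 1.3-fold higher number from compound 2 to compound 3 (0.12 log units; within the scatter) and so does not separate the two compounds. Chloro in place of fluoro, at a different place on the shared core, gives a 1.6-fold higher number from compound 1 to compound 3 (0.20 log units; within the scatter) and does not separate them either. Each of these two places now has a single-change comparison, and neither change moves the number beyond the usual scatter. No measurement here offers an explanation for these small differences.

Still open, on these data alone, is whether a group of another kind at either place, such as an amine or a carboxylic acid, would shift the number beyond the scatter.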